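Ester to acid swap on the aryl ether end

The source may hold more compounds than are shown below. What is called first, only, known or untested is meant among the compounds shown, and "the series" means these compounds.

Measured so far:
compound 1 `COC(=O)c1ccc(OCCCCOc2ccc(C(=O)CC3CCCC3)c(C)c2C)cc1`: 14.1%
compound 2 `COC(=O)c1ccc(OCCCCOc2ccc(C(=O)CC(C)C)c(C)c2C)cc1`: 15.9%

In an assay on HEK293 cells for positive allosteric modulation of metabotropic glutamate receptor 2 (Rattus norvegicus), read by thallium flux, with a stated time of 2.5 min (on this read-out higher numbers stand for larger maximal responses and lower numbers for smaller maximal responses), compound 1 stands lowest of the two numbers, with compound 2 nearest; the step of a number 1.8 percentage points higher from compound 1 to compound 2 (within the scatter) lies within the scatter. Compound 3 `Cc1c(OCCCCOc2ccc(F)c(C(=O)O)c2)ccc(C(=O)CC2CCCC2)c1C` is not yet measured. It differs from compound 1 by 3-carboxy-4-fluorophenyl in place of 4-(methoxycarbonyl)phenyl on an oxygen on a saturated carbon. Within the data shown here, no measured step touches this end of the molecule; the only known step alters the group on the carbonyl side and is within the scatter. Because compound 1 gives 14.1%, which is low, compound 3 is expected near it, with a wide range, so a number 1.9 percentage points higher from compound 1 to compound 3 (within the scatter) is the expected step. Compound 3 is therefore estimated at 16%, between 4% and 40%.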

Compound 3, largest response reached (reported as percent of maximum), in percent of the reference or control that the assay uses: 14.6%
Compound 3: middle estimate off by 1.4 percentage points, on the high side, within the range that was stated.
By their numbers in this assay, from the lowest: compounds 1, 3 and 2 (each within the scatter of the next).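

In this assay, 3-carboxy-4-fluorophenyl in place of 4-(methoxycarbonyl)phenyl on an oxygen on a saturated carbon gives a number 0.5 percentage points higher from compound 1 to compound 3 (within the scatter) in the maximal response. The aryl ether end, untouched by the earlier step, therefore also shows no change beyond the scatter, even though this swap adds a hydrogen-bond donor and a fluorine. No available data bear on the reason for this result. From the compounds shown here alone, the separate contributions of the carboxylic acid and the fluorine remain open. So does the effect of a tetrazole or a primary amide at this end.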